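This account rests on a few compounds, and the source may have more. Where it says the series, first, only, none or still open, it means among the compounds named here.

Measured in an assay on isolated protein for inhibition of tyrosine-protein kinase receptor UFO (Homo sapiens), read by ELISA; on this read-out lower numbers stand for stronger inhibition and higher numbers for weaker inhibition:

Compound 1 `Cn1cc(-c2ccc(NC(=O)c3cn(CC4CCCO4)cc(-c4ccc(F)cc4)c3=O)cc2)c2c(N)ncnc21` gives 1.2 nM.
Compound 2 `Nc1ncnc2[nH]cc(-c3ccc(NC(=O)c4cn(CC5CCOCC5)cc(-c5ccc(F)cc5)c4=O)cc3)c12` gives 0.2 nM.
Compound 3 `Cn1cc(-c2ccc(NC(=O)c3cn(CC4CCOCC4)cc(-c4ccccc4)c3=O)cc2)c2c(N)ncnc21` gives 1 nM.

Of these three numbers, compound 1 holds the highest, so it is the weakest inhibitor on this read-out. Its nearest neighbour is compound 3, whose number lies within the usual scatter of the value for compound 1, so the two cannot be told apart. Compound 2 sits furthest away, with a number well beyond the scatter, so compound 2 is a clearly stronger inhibitor than compound 1.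

Compound 4 `Cn1cc(-c2ccc(NC(=O)c3cn(C4CCOCC4)cc(-c4ccc(F)cc4)c3=O)cc2)c2c(N)ncnc21` has not yet been measured. It shares every atom with compound 1, but the atoms are joined differently: oxan-4-yl in place of (oxolan-2-yl)methyl on an aromatic nitrogen. For the measured compounds named here, no step between two measured compounds shows this exact change, so the expectation rests on compound 1 alone and on the observation that compounds 2 and 3, which carry a different six-membered ring group in the same place, stay in the same low range.

The step from compound 1 to compound 4 is expected to be small, no change at the digits printed from compound 1 to compound 4 (within the scatter), with no clear direction beyond the scatter. Compound 4 is therefore estimated to give 1.2 nM, most likely between 0.4 nM and 4 nM.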

Compound 4, half-maximal inhibitory concentration: 1.1 nM
For compound 4 the middle estimate is 1.1-fold (0.04 log units) above the measured one, and the stated range covers the measured number.
By their numbers in this assay, from the lowest: compound 2; then compounds 3, 4 and 1 (each within the scatter of the next).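

In this assay, rejoining the same atoms on the aromatic nitrogen, from (oxolan-2-yl)methyl to oxan-4-yl, gives a 1.1-fold lower number from compound 1 to compound 4 (0.04 log units; within the scatter) and so leaves the two compounds indistinguishable. This is the first pair shown that differs at this position alone, so the position can now be judged without another change in the molecule confusing the comparison: here, a five-membered ring carried on a methyl link gives way to a six-membered ring attached directly, and this single change produces no step beyond the scatter. Nothing available explains why these two groups give values that cannot be told apart.

For the compounds shown here, this single pair shows tolerance for only one exchange between two groups with the same atoms, each holding one ring oxygen, so it cannot show how far that tolerance extends. Open questions are whether a piperidin-4-yl ring, with an amine in place of the ring oxygen, a plain cyclohexyl ring, or a longer chain ending in a carboxylic acid would stay in the same range on the aromatic nitrogen.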